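This account rests on a few compounds, and the source may have more. Where it says the series, first, only, none or still open, it means among the compounds named here.

Among the compounds with values here, in an ADME assay on PBMC cells (Homo sapiens) for cytotoxicity, with a stated time of 5 days (a lower number here means a stronger inhibitor, a higher number a weaker inhibitor), compound 3 `Cc1ccsc1C1=NNC(c2ccc(N3CCCCC3)cc2)C1` supplies the only number among the three compounds measured, giving 11000 nM. Compound 1 `O=C(/C=C/c1ccc(N2CCCCC2)cc1)c1ccsc1` gives only a limit of this assay, > 100000 nM. Compound 2 `O=C(/C=C/c1ccc(N2CCCCC2)cc1)c1ccc(Cl)s1` likewise gives only a limit, > 100000 nM. Within the data shown here, the single measured step, a step that the two limits leave unreadable from compound 1 to compound 2, is therefore unreadable, as the limit of > 100000 nM in this assay, at which 2 of the 3 values shown sit, records. Compound 4 `Ic1ccc(C2=NNC(c3ccc(N4CCCCC4)cc3)C2)s1` differs from compound 3 by 5-iodothiophen-2-yl in place of 3-methylthiophen-2-yl on a carbon with a double bond to nitrogen. Among the measured compounds shown here, no measured step touches this kind of exchange on the core of compound 3, so no size can be read across to it; a change within the scatter is expected, a 1.1-fold lower number from compound 3 to compound 4 (0.04 log units; within the scatter). Compound 4 is accordingly estimated at 10000 nM in this assay, within a range of 3000 nM to 40000 nM.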

Compound 4, half-maximal inhibitory concentration: > 100000 nM
Compound 4: a limit, no number; the forecaster's own chance of this, stated with the estimate: 15%; middle value at least 10-fold (1.00 log units) away from the limit.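

Within the data shown here, on the core of compound 3, 5-iodothiophen-2-yl in place of 3-methylthiophen-2-yl gives the only readable step in this assay: an at least 9.0-fold higher number from compound 3 to compound 4 (0.95 log units; beyond the scatter). Compound 4 gives a limit, not a number, so this size is only a bound: the limit of > 100000 nM in this assay, at which 3 of the 4 values shown sit. The group on this carbon with a double bond to nitrogen can thus move the read-out beyond the scatter, which the unreadable step from compound 1 to compound 2 could not show.

From the compounds shown here alone, the iodine and the loss of the methyl come together here, so which of them carries the step stays open. Going by these compounds, how a plain thiophen-2-yl or a carboxylic acid would read at this place also stays open.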